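A Third Methoxy Group on the Carbonyl-Bearing Ring

The compounds below may be only part of what the source reports. "The series", "measured", "known", "first", "only" and "open" are said of these compounds alone.

Three analogues share one core: compound 1 `COc1cc(-c2cc(/C=C/C(=O)c3ccc(Cl)c(Cl)c3)[nH]n2)cc(OC)c1OC`, compound 2 `COc1ccc(-c2cc(/C=C/C(=O)c3cc(OC)c(OC)c(OC)c3)[nH]n2)cc1OC` and compound 3 `COc1ccc(C(=O)/C=C/c2cc(-c3cc(OC)c(OC)c(OC)c3)n[nH]2)cc1OC`. In a functional assay on TK-10 cells (Homo sapiens) for cytotoxicity, read by sulforhodamine B assay, with a stated time of 48 h, tested at 1 uM (a lower number here means a stronger effect, a higher number a weaker effect of the compound at the concentration tested), compound 1 gives 93% and compound 2 gives 96%, while compound 3 gives 71%, the lowest of the three numbers. For the measured compounds named here, the only single-point step measured, a number 22 percentage points lower from compound 1 to compound 3 (beyond the scatter), shows that exchanging the ring on the carbonyl carbon can move the read-out beyond the scatter. Compound 4 `COc1cc(C(=O)/C=C/c2cc(-c3cc(OC)c(OC)c(OC)c3)n[nH]2)cc(OC)c1OC` differs from compound 3 by methoxy in place of hydrogen on an aromatic carbon. Going by the values given here, no measured step covers this change; compound 2, which carries a differently substituted ring on the carbonyl carbon, shows a higher number than compound 3. A modest rise is therefore expected, the expected step being a number 10 percentage points higher from compound 3 to compound 4 (within the scatter). Compound 4 is estimated at 81%, with a range from 62% to 98%.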

Compound 4, a percentage reported as activity, at one concentration (the size of the read-out at that concentration, not a potency): 80%
The estimate for compound 4 lay 1 percentage points above the measured number; the measured number falls inside the stated range.
By their numbers in this assay, from the lowest: compounds 3 and 4 (each within the scatter of the next); then compounds 1 and 2 (each within the scatter of the next).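

In this assay there is a number 9 percentage points higher from compound 3 to compound 4 (within the scatter) for methoxy in place of hydrogen on the ring on the carbonyl carbon, so at this position the added group leaves the read-out within the scatter. The same exchange on the other aromatic ring gives a number 16 percentage points lower from compound 2 to compound 4 (beyond the scatter) and thus, in these two pairs, the outcome depends on which ring carries the methoxy. Nothing at hand bears on the reason for this difference.

As far as these compounds go, whether an amine or a hydroxyl on this aromatic carbon would act like methoxy remains open. So does the effect of a longer chain, such as ethoxy, there.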